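The source may hold more compounds than are shown below. What is called first, only, known or untested is meant among the compounds shown, and "the series" means these compounds.

Among the compounds with values here, in a functional assay on CWR22R cells (Homo sapiens) for antiproliferative activity, read by propidium iodide staining, with a stated time of 96 h (on this read-out higher numbers stand for weaker inhibition and lower numbers for stronger inhibition), three compounds have numbers so far. Compound 1 (`CC(O)(CS(=O)(=O)c1ccc(S(F)(F)(F)(F)F)cc1)C(=O)Nc1ccc([N+](=O)[O-])c(C(F)(F)F)c1`) gives 14700 nM and compound 2 (`CC(O)(CS(=O)(=O)c1cccc(C(F)(F)F)c1)C(=O)Nc1ccc(S(F)(F)(F)(F)F)cc1`) gives 23800 nM while compound 3 (`CC(O)(CS(=O)(=O)c1cc(C(F)(F)F)cc(C(F)(F)F)c1)C(=O)Nc1ccc(S(F)(F)(F)(F)F)cc1`) gives 12700 nM. These three numbers lie within the usual scatter of one another, so compound 3 cannot be told apart from either neighbour on this read-out.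

Compound 4 (`CC(O)(CS(=O)(=O)c1cc(C(F)(F)F)cc(C(F)(F)F)c1)C(=O)Nc1cccc(S(F)(F)(F)(F)F)c1`) has the same atoms as compound 3, joined differently. The change is a group of 12 heavy atoms (6 carbon, 5 fluorine, 1 sulfur; one six-membered aromatic ring of carbon only) in place of a group of 12 heavy atoms (6 carbon, 5 fluorine, 1 sulfur; one six-membered aromatic ring of carbon only), on an amide-type nitrogen. It sits on an amide-type nitrogen, and the rest of the molecule stays as it was.

Within the data shown here, only one measured step links two compounds that differ in one place, and that is a 1.9-fold lower number from compound 2 to compound 3 (0.27 log units; within the scatter). It lies within the scatter and concerns trifluoromethyl in place of hydrogen on an aromatic carbon, so it is a different change and does not test this one. Among the measured compounds shown here, the data therefore hold no direct precedent, and the expectation rests on the narrow spread of the three numbers. No shift beyond the scatter is expected in this assay, in either direction.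

The expected step is a 1.2-fold higher number from compound 3 to compound 4 (0.07 log units; within the scatter), which would stay within the scatter. For compound 4 the estimated value is 15000 nM, with an expected range from 6000 nM to 35000 nM.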

Compound 4, half-maximal inhibitory concentration: 9300 nM
For compound 4 the middle estimate is 1.6-fold (0.21 log units) above the measured one; low and high end bracket the measured number.
By their numbers in this assay, from the lowest: compounds 4, 3, 1 and 2 (each within the scatter of the next, the first and the last beyond it).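

Compound 3 and compound 4 carry groups on the amide-type nitrogen that have the same atoms, joined differently, and in this assay the exchange gives a 1.4-fold lower number from compound 3 to compound 4 (0.14 log units; within the scatter) on this read-out, so the two compounds cannot be told apart. Within the data shown here, this is the first measured step at this place, since the only earlier one, a 1.9-fold lower number from compound 2 to compound 3 (0.27 log units; within the scatter), concerned trifluoromethyl in place of hydrogen on an aromatic carbon and left the group on the amide-type nitrogen as it was. Nothing available here bears on why the exchange leaves the number within the scatter.

On these data alone, with a single step at this place, it stays open whether the same exchange would also stay within the scatter on the core of compound 2, which carries one trifluoromethyl where compound 3 carries two. As far as these compounds go, it also stays open whether a group on the amide-type nitrogen whose aromatic ring bears a nitrile or an amine would give a number that differs beyond the scatter from those of compound 3 and compound 4.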